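Replacing the ester group of compound 2

The source may report more compounds than this note shows. Statements on the series, on what has been measured and on what is new or still open speak of the compounds shown alone.

In an ADME assay on HepG2 2.2.15 cells (Homo sapiens) for cytotoxicity (on this read-out lower numbers stand for higher toxicity in this test and higher numbers for lower toxicity in this test), compound 1 `N#CCC(=O)OCCc1c(-c2ccccc2Cl)c2cc(Cl)ccc2[nH]c1=O` gives 100000 nM. Compound 2 `CC12CCC(C(=O)OCCc3c(-c4ccccc4Cl)c4cc(Cl)ccc4[nH]c3=O)(OC1=O)C2(C)C` reads > 1800000 nM, which is a limit of the assay and not a number. Among the measured compounds shown here, the only measured step at this carbonyl carbon, an at least 18-fold higher number from compound 1 to compound 2 (1.25 log units; beyond the scatter), was large and beyond the usual scatter. For the measured compounds named here, compound 3 `O=C(OCCc1c(-c2ccccc2Cl)c2cc(Cl)ccc2[nH]c1=O)c1cccnc1` carries a group of 6 heavy atoms (5 carbon, 1 nitrogen; one six-membered aromatic ring with 1 hetero atom) in place of a group of 11 heavy atoms (9 carbon, 2 oxygen; one five-membered non-aromatic ring of carbon only, one five-membered non-aromatic ring with 1 hetero atom), on a carbonyl carbon, so it gives up the group that compound 2 gained in that step, and only this one step bears on it. A clear fall in this assay is therefore expected, namely an at least 6.0-fold lower number from compound 2 to compound 3 (0.77 log units; beyond the scatter). For compound 3 the estimated value is 300000 nM, with an expected range of 60000 nM to 1500000 nM.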

Compound 3, half-maximal cytotoxic concentration: 170000 nM
Compound 3: the middle estimate sits 1.8-fold (0.25 log units) above what was measured; the range from low to high includes it.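

In this assay, pyridin-3-yl on this carbonyl carbon gives an at least 10-fold lower number from compound 2 to compound 3 (1.02 log units; beyond the scatter), so the high reading of compound 2 does not carry over to this other ring-bearing group. Against cyanomethyl, the same group gives a 1.7-fold higher number from compound 1 to compound 3 (0.23 log units; within the scatter), so a ring alone does not separate these two compounds in this test. The reading of compound 2 is a limit of the assay and not a number: the limit of > 1800000 nM in this assay, at which 1 of the 3 values shown sits.

As far as these compounds go, how far compound 2 truly lies from the others stays open. So does whether a butyl chain or a carboxylic acid on this carbon would read like compound 2 or like compound 3.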